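This account rests on a few compounds, and the source may have more. Where it says the series, first, only, none or still open, it means among the compounds named here.

In a physicochemical assay for lipophilicity, at pH 7.4 (on this read-out lower numbers stand for lower lipophilicity and higher numbers for higher lipophilicity), compound 1 `CS(=O)(=O)N1C[C@H](C(=O)Nc2ccc(Cl)cc2)[C@@H](C(=O)Nc2ccc(-n3ccccc3=O)cc2F)C1` gives 2.17 and compound 2 `CCS(=O)(=O)N1C[C@H](C(=O)Nc2ccc(Cl)cc2)[C@@H](C(=O)Nc2ccc(-n3ccccc3=O)cc2F)C1` gives 2.44 so the two lie within the scatter of each other. Compound 3 `NS(=O)(=O)N1C[C@H](C(=O)Nc2ccc(Cl)cc2)[C@@H](C(=O)Nc2ccc(-n3ccccc3=O)cc2F)C1` is still unmeasured and differs from compound 2 by the change amino in place of ethyl on a sulfonyl sulfur. For the measured compounds named here, the one measured step that bears on it is a number 0.27 log units higher from compound 1 to compound 2 (within the scatter) which stays within the scatter and concerns methyl in place of hydrogen on a saturated chain carbon bound to a sulfonyl sulfur. Going by the values given here, no measured compound carries the amino group, so this guide is weak. Taking compound 1 at 2.17 as the guide, a modest downward step in this assay is expected. The estimated step is a number 0.39 log units lower from compound 2 to compound 3 (beyond the scatter) and it remains uncertain. For compound 3 the expected value is 2.05 with an estimated range of 1.7 to 2.4 still to be tested.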

Compound 3, distribution coefficient: 1.83
Beside the measured number, compound 3's estimate is 0.22 log units above it; measured number inside the range.
By their numbers in this assay, from the lowest: compound 3; then compounds 1 and 2 (each within the scatter of the next).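

In this assay, for the compounds shown here, the place on the sulfonyl sulfur now shows a change that clears the scatter: amino in place of ethyl gives a number 0.61 log units lower from compound 2 to compound 3 (beyond the scatter), and amino in place of methyl gives a number 0.34 log units lower from compound 1 to compound 3 (beyond the scatter), whereas the one earlier step here stayed within it. Going by these compounds alone, compound 3 therefore stands lowest of the three, set apart from both compound 1 and compound 2, and amino is the only group on that sulfur here that is not a carbon chain. Nothing available explains the size of these steps.

Going by these compounds, it remains open whether a methylamino or dimethylamino group on the same sulfur would stay near compound 3 or return towards compound 1 and compound 2. A longer chain such as propyl is also untested among these compounds, and all three share one core, so the steps cannot be extended to any other.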